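Removing One Bromo From Compound 1

A few compounds are considered here, and "the series" means these few. Any claim that something is new, unique, unknown or untested is made for them only; others in the source may bear on it.

In a functional assay on PC-3 cells (Homo sapiens) for cytotoxicity, read by CCK-8 assay, with a stated time of 72 h (on this read-out lower numbers stand for stronger inhibition and higher numbers for weaker inhibition), compound 1 `CCOC(=O)CC1CNC(=O)c2cc(Br)c(Br)n21` gives 39000 nM, the lowest number shown, and compound 2 `COC(=O)Cc1c[nH]c(=O)c2ccc(Br)n12` follows at 176000 nM. Compound 3 `COC(=O)Cc1c[nH]c(=O)c2cccn12` reaches only a limit, > 200000 nM.

Compound 4 `CCOC(=O)CC1CNC(=O)c2ccc(Br)n21` differs from compound 1 by hydrogen in place of bromo on an aromatic carbon, with hydrogen in place of bromo on an aromatic carbon. One measured step makes the same swap, on a different core and at a different bromo: an at least 1.1-fold higher number from compound 2 to compound 3 (0.05 log units; that floor lies within the scatter). From the compounds shown here alone, its true size stays open because of the limit of > 200000 nM in this assay, at which 1 of the 3 values shown sits. A moderate move towards weaker inhibition is therefore expected, estimated as a 2.2-fold higher number from compound 1 to compound 4 (0.34 log units; beyond the scatter). Compound 4 is expected at 85000 nM, with an estimated range of 35000 nM to 200000 nM.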

Compound 4, half-maximal inhibitory concentration: 29000 nM
For compound 4 the middle estimate is 2.9-fold (0.47 log units) above the measured one; measured number outside the range, below it.
By their numbers in this assay, from the lowest: compounds 4 and 1 (each within the scatter of the next); then compound 2. At a limit, above all of these: compound 3.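

In this assay, replacing this bromo with hydrogen gives a 1.3-fold lower number from compound 1 to compound 4 (0.13 log units; within the scatter), so on the core of compound 1 the number holds with hydrogen on this aromatic carbon. Compound 3 stands at a limit, > 200000 nM, so the earlier step gave no measured size for this change. Set side by side, the two cases cannot be separated: the same change on two cores in this assay, an at least 1.1-fold higher number (0.05 log units; that floor lies within the scatter) from compound 2 to compound 3 and a 1.3-fold lower number (0.13 log units; within the scatter) from compound 1 to compound 4; the limit leaves it open whether they differ

The compounds shown leave open how an amine or a carboxylic acid on this aromatic carbon would read. They also leave open what replacing the remaining bromo of compound 4 with hydrogen would do on this core.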